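The source may report more compounds than this note shows. Statements on the series, on what has been measured and on what is new or still open speak of the compounds shown alone.

Compound 1, `Cc1c(C(=O)Nc2c(F)cc(-c3cccc(F)c3)cc2F)nc2ccc(F)cc2c1O`: -0.12%
Compound 2, `Cc1c(C(=O)Nc2c(F)cc(-c3cccc(F)c3)cc2F)nc2ccc(OC(F)(F)F)cc2c1O`: 0.32%
Compound 3, `Cc1c(C(=O)Nc2c(F)cc(-c3cccc(F)c3)cc2F)nc2ccc(C(F)(F)F)cc2c1O`: -0.33%

The three compounds share one core and differ only in the group on an aromatic carbon. In a functional assay on Hep 3B2 cells (Homo sapiens) for antiproliferative activity, read by MTT assay, with a stated time of 24 h, tested at 0.01 ug/mL (on this read-out higher numbers stand for a stronger effect at the one concentration tested and lower numbers for a weaker effect), all three numbers lie close to zero. Compound 3 is separated from the others by a number 0.2 percentage points lower from compound 1 to compound 3 (within the scatter) and by a number 0.7 percentage points lower from compound 2 to compound 3 (within the scatter), and the remaining pair shows a number 0.4 percentage points higher from compound 1 to compound 2 (within the scatter).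

Compound 4, `Cc1c(C(=O)Nc2c(F)cc(-c3cccc(F)c3)cc2F)nc2ccc(C(F)(F)F)cc2c1C(=O)O`, is not yet measured. It departs from compound 3 in this way: carboxy in place of hydroxy on an aromatic carbon. None of the three measured steps touches the hydroxy; each of them swaps the fluoro, trifluoromethoxy or trifluoromethyl group on another aromatic carbon, and each lies within the scatter. The carboxy therefore enters without a comparable measured change to lean on, while the measurements so far give no sign of any movement in this assay at this concentration. Compound 4 is thus expected to show a number 0.3 percentage points higher from compound 3 to compound 4 (within the scatter), nothing beyond the scatter. The estimate for compound 4 is 0%, within -5% to 5%.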

Compound 4, a percentage reported as inhibition, at one concentration (the size of the read-out at that concentration, not a potency): 0.2%
Estimate against measurement, compound 4: 0.2 percentage points below; the range from low to high includes it.
By their numbers in this assay, from the lowest: compounds 3, 1, 4 and 2 (each within the scatter of the next).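

Carboxy in place of hydroxy on the aromatic carbon opposite the ring nitrogen gives a number 0.5 percentage points higher from compound 3 to compound 4 (within the scatter) in this assay. Going by these compounds alone, this is the first measured change at this position, which none of the earlier steps touched, and here three heavy atoms enter where one leaves without taking the number outside the scatter. Nothing shown accounts for this outcome.

With all four numbers close to zero at the one concentration tested, the compounds shown leave open whether hydroxy and carboxy would differ at a concentration where an effect appears. They also leave open whether an amine or a methyl ester at this position, or carboxy paired with fluoro or trifluoromethoxy on the other aromatic carbon, would read any differently.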